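The source may report more compounds than this note shows. Statements on the series, on what has been measured and on what is new or still open speak of the compounds shown alone.

Compound 1 `COc1ccc(OCCCCOc2ccc(C(=O)CC(C)(C)C)c(O)c2C)cc1C(=O)O` gives 13 nM in an assay for positive allosteric modulation of metabotropic glutamate receptor 2 (Rattus norvegicus); on this read-out higher numbers stand for an effect only at larger amounts of compound and lower numbers for an effect already at smaller amounts.
Compound 2 `Cc1ccc(C(=O)O)cc1OCCCCOc1ccc(C(=O)CC(C)(C)C)c(O)c1C` gives 512 nM in this assay.

Of the two measured compounds, compound 2 has the higher number, and its gap to compound 1 lies beyond the usual scatter. Compound 3 `Cc1c(OCCCCOc2ccc(F)c(C(N)=O)c2)ccc(C(=O)CC(C)(C)C)c1O` is built from compound 2 by a single change: 3-carbamoyl-4-fluorophenyl in place of 5-carboxy-2-methylphenyl on an oxygen on a saturated carbon. For the measured compounds named here, no measured pair shows this change, so its direction is open; a step of modest size either way, or none beyond the scatter, is the cautious expectation. Compound 3 is expected to give 600 nM, within 120 nM to 3000 nM, an estimated step of a 1.2-fold higher number from compound 2 to compound 3 (0.07 log units; within the scatter).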

Compound 3, half-maximal effective concentration: > 10000 nM
Compound 3 was reported as a limit (the forecaster's own chance of this, stated with the estimate: 10%); middle value at least 16-fold (1.22 log units) from the limit.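

Putting 3-carbamoyl-4-fluorophenyl in place of 5-carboxy-2-methylphenyl brings an at least 19-fold higher number from compound 2 to compound 3 (1.29 log units; beyond the scatter), so this place does not accept every group of the same heavy-atom count, even with matching donor and acceptor counts. In this assay compound 3 stands only as a limit, > 10000 nM, not as a number.

The change swaps carboxy, methyl, carbamoyl and fluorine together, so the compounds shown cannot tell which of these parts accounts for the step. On these data alone, whether a tetrazole or a nitrile on this ring would keep the effect also stays open.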